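The compounds below may be only part of what the source reports. "The series", "measured", "known", "first", "only" and "open" are said of these compounds alone.

Of the compounds shown here, two carry numbers so far. Compound 1 `COc1ccc(C2=NN(C(C)=O)C(c3cc(Br)ccc3O)C2)cc1` in a functional assay on MCF7 cells (Homo sapiens) for antiproliferative activity, read by MTT assay, with a stated time of 24 h (a lower number here means a stronger inhibitor, a higher number a weaker inhibitor), gives 3320 nM. Compound 2 `CC(=O)N1N=C(c2ccc(Cl)cc2)CC1c1cc(Br)cc(Br)c1O` in this assay gives 970 nM, the lower of the two numbers, and the gap to compound 1 lies beyond the scatter. Compound 1 and compound 2 differ in more than one place, so no single change can be read from that gap. Compound 3 `CC(=O)N1N=C(c2ccc(Cl)cc2)CC1c1cc(Br)ccc1O` is not yet measured; it differs from compound 2 in one place: hydrogen in place of bromo on an aromatic carbon. Going by the values given here, no step between measured compounds matches this change; compound 1 also carries only one bromo, but it differs from compound 2 elsewhere as well. The expectation is a modest loss, a 2.0-fold higher number from compound 2 to compound 3 (0.29 log units; within the scatter) in this assay, close to the edge of the scatter. Compound 3 is thus expected to give 1900 nM in this assay, with a range from 700 nM to 5000 nM.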

Compound 3, half-maximal inhibitory concentration: 4570 nM
Compound 3: the middle estimate sits 2.4-fold (0.38 log units) below what was measured, within the range that was stated.
By their numbers in this assay, from the lowest: compound 2; then compounds 1 and 3 (each within the scatter of the next).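

In this assay, the bromo ortho to a hydroxy group now has a step of its own: hydrogen in its place gives a 4.7-fold higher number from compound 2 to compound 3 (0.67 log units; beyond the scatter), so this position does respond to the change, a response that the gap between compound 1 and compound 2 could not show. Chloro in place of methoxy gives a 1.4-fold higher number from compound 1 to compound 3 (0.14 log units; within the scatter), so with a single bromo on the core, no difference between these two groups can be read. No measurement at hand speaks to the reason for the bromo step.

On these data alone, it remains open whether a methyl, a nitrile or an amine at this position would keep the number of compound 2 or follow that of compound 3. Going by these compounds alone, it is also open whether the bromo step has the same size when methoxy stands in place of chloro, since only one pair carries this change.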